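The source may report more compounds than this note shows. Statements on the series, on what has been measured and on what is new or still open speak of the compounds shown alone.

Measured compounds:
compound 1, `O=C(NO)c1cccc(-c2cn([C@H]3C[C@H](CO)N(CCCc4ccccc4)C3)nn2)c1`, < 10%
compound 2, `O=C(/C=C/c1cn([C@H]2C[C@H](CO)N(CCCc3ccccc3)C2)nn1)NO`, 16%
compound 3, `O=C(NO)c1cccc(-c2cn([C@@H]3C[C@@H](C(=O)O)N(CCCc4ccccc4)C3)nn2)c1`, < 10%

In an assay on Sf9 cells for inhibition of histone deacetylase 11 (Homo sapiens), read by fluorescence, tested at 0.5 uM (a higher number here means more inhibition at the concentration tested (going by the name of the read-out), a lower number less inhibition), compound 1 gives < 10%, which is a limit of the assay and not a number. Compound 2 gives 16%. The change 2-(hydroxycarbamoyl)ethenyl in place of 3-(hydroxycarbamoyl)phenyl on an aromatic carbon brings a number at least 6 percentage points higher from compound 1 to compound 2 (that floor lies within the scatter). Compound 3 gives < 10%, again a limit of the assay. How the core of compound 3 differs from the core of compound 1 is not broken down here. Compound 4, `O=C(/C=C/c1cn([C@@H]2C[C@@H](C(=O)O)N(CCCc3ccccc3)C2)nn1)NO`, carries the same change as compound 2 does, (2-(hydroxycarbamoyl)ethenyl in place of 3-(hydroxycarbamoyl)phenyl on an aromatic carbon). The values of compound 1 and compound 3 both sit at the same limit. Because of the limit of < 10% in this assay, at which 2 of the 3 values shown sit, the same change is expected to bring a step of a size similar to a number at least 6 percentage points higher from compound 1 to compound 2 (that floor lies within the scatter). The expected step is a number at least 2 percentage points higher from compound 3 to compound 4 (that floor lies within the scatter). Compound 4 is therefore estimated at 12%, within 3% to 22%.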

Compound 4, a percentage reported as inhibition, at one concentration (the size of the read-out at that concentration, not a potency): < 10%
Compound 4 gave a limit, no number; the forecaster's own chance of this, stated with the estimate: 40%; middle value at least 2 percentage points from the limit.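

The step from compound 3 to compound 4 cannot be read, because compound 4 also stops at a limit rather than a number: the limit of < 10% in this assay, at which 3 of the 4 values shown sit.

The compounds shown leave open what 2-(hydroxycarbamoyl)ethenyl in place of 3-(hydroxycarbamoyl)phenyl does on the core of compound 3.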